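A few compounds are considered here, and "the series" means these few. Any claim that something is new, unique, unknown or untested is made for them only; others in the source may bear on it.

Measured in a functional assay (trachea) with Cavia porcellus as the target; on this read-out higher numbers stand for an effect only at larger amounts of compound and lower numbers for an effect already at smaller amounts:
- compound 1 `CCCn1c(=O)n(CCC#N)c(=O)c2[nH]cnc21`: 1700 nM
- compound 2 `CCCn1c(=O)n(C)c(=O)c2c1ncn2CCC(=O)O`: > 100000 nM

Of the two, only compound 1 gives an actual number, 1700 nM. Compound 2 gives only a limit of the assay, > 100000 nM, and no number.

The next compound, compound 3 `CCCn1c(=O)n(C)c(=O)c2c1ncn2CCCN(C)C`, changes compound 2 in one place. It has (dimethylamino)methyl in place of carboxy on a saturated chain carbon, two bonds along the chain from an aromatic nitrogen. Read one bond further out, this is 2-carboxyethyl to 3-(dimethylamino)propyl.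

Among the compounds with values here, no measured step shows what this exchange does in this assay, so the expectation rests on little. Since compound 2 stands at > 100000 nM, a number for compound 3 could only lie toward smaller amounts, and that is the direction expected. The expected change is an at least 3.3-fold lower number from compound 2 to compound 3 (0.52 log units; beyond the scatter), a sizeable move that could still prove small. Compound 3 is not expected to reach compound 1, at 1700 nM. For compound 3 the estimated value is 30000 nM, with an expected range from 6000 nM to 100000 nM.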

Compound 3, half-maximal effective concentration: > 100000 nM
Compound 3 gave a limit, no number; the forecaster's own chance of this, stated with the estimate: 25%; middle value at least 3.3-fold (0.52 log units) away from the limit.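

Like compound 2, compound 3 gives no number in this assay, only a limit of the assay, so no step can be read between compound 2 and compound 3: the limit of > 100000 nM in this assay, at which 2 of the 3 values shown sit.

The compounds shown leave open whether (dimethylamino)methyl in place of carboxy changes the effect in this assay at all.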